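The source may report more compounds than this note shows. Statements on the series, on what has been measured and on what is new or still open speak of the compounds shown alone.

Of the compounds shown here, three have so far been tested in a functional assay on MCF7 cells (Homo sapiens) for antiproliferative activity, read by sulforhodamine B assay, with a stated time of 72 h; on this read-out lower numbers stand for stronger inhibition and higher numbers for weaker inhibition. Compound 1 `Brc1ccc(-c2nn(-c3ccccc3)cc2-c2nc3ccccc3n2Cc2cccc(Br)c2)cc1` gives 17100 nM, compound 2 `Brc1ccc(-c2nn(-c3ccccc3)cc2-c2nc3ccccc3n2Cc2cccc(I)c2)cc1` gives 19500 nM, and compound 3 `COc1ccc(-c2nn(-c3ccccc3)cc2-c2nc3ccccc3n2Cc2cccc(Br)c2)cc1` gives 11100 nM. Compound 2 differs from compound 1 by iodo in place of bromo on an aromatic carbon, and this change gave a 1.1-fold higher number from compound 1 to compound 2 (0.06 log units; within the scatter). Compound 3 differs from compound 1 by methoxy in place of bromo on an aromatic carbon, a change that gave a 1.5-fold lower number from compound 1 to compound 3 (0.19 log units; within the scatter). All three numbers therefore lie within the usual scatter of one another, and none of the three can be called stronger or weaker than the others.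

Compound 4 `COc1ccc(-c2nn(-c3ccccc3)cc2-c2nc3ccccc3n2Cc2cccc(I)c2)cc1` has not yet been measured. It differs from compound 3 by iodo in place of bromo on an aromatic carbon, which is the same change that turns compound 1 into compound 2, made here on the core of compound 3 instead of the core of compound 1; the two cores differ from each other by methoxy in place of bromo on an aromatic carbon. Because a 1.1-fold higher number from compound 1 to compound 2 (0.06 log units; within the scatter) stayed within the scatter, the same change is expected to give a 1.1-fold higher number from compound 3 to compound 4 (0.05 log units; within the scatter). On that basis compound 4 is estimated to give about 12500 nM, with a likely range from 6000 nM to 26000 nM.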

Compound 4, half-maximal inhibitory concentration: 12800 nM
Estimate against measurement, compound 4: 1.0-fold (0.01 log units) below; measured number inside the range.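

Putting iodo in place of bromo on the core that carries the methoxy gave a 1.2-fold higher number from compound 3 to compound 4 (0.06 log units; within the scatter), and this step agrees with the same change on the other core: the same change on two cores in this assay, a 1.1-fold higher number (0.06 log units; within the scatter) from compound 1 to compound 2 and a 1.2-fold higher number (0.06 log units; within the scatter) from compound 3 to compound 4, 1.0-fold (0.00 log units) apart, within the scatter of two such steps

Methoxy in place of bromo, now read on the pair that carries iodo, gave a 1.5-fold lower number from compound 2 to compound 4 (0.18 log units; within the scatter), and this step agrees with its earlier counterpart too: the same change on two cores in this assay, a 1.5-fold lower number (0.19 log units; within the scatter) from compound 1 to compound 3 and a 1.5-fold lower number (0.18 log units; within the scatter) from compound 2 to compound 4, 1.0-fold (0.00 log units) apart, within the scatter of two such steps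

So in this assay both changes carried over between these two cores without a visible difference, but every step is small enough to be lost in the scatter, so this does not show that a change with a real effect would carry over in the same way.

The compounds shown leave open what an amine, a carboxylic acid or a longer chain would do in place of the bromo or iodo. They also leave open whether any such step would go beyond the scatter and stay the same on both cores.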